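Urea ACAT Inhibitors: Swapping Tert-Butyl for Chloro

The compounds below may be only part of what the source reports. "The series", "measured", "known", "first", "only" and "open" are said of these compounds alone.

Compound 1 `Cc1ccccc1C1(CNC(=O)Nc2c(C(C)C)cccc2C(C)C)CCCC1`: 17 nM
Compound 2 `Cc1cccc(C2(CNC(=O)Nc3c(C(C)C)cccc3C(C)C)CCCC2)c1`: 15 nM
Compound 3 `CC(C)c1cccc(C(C)C)c1NC(=O)NCC1(c2ccc(C(C)(C)C)cc2)CCCC1`: 63 nM

Of the compounds shown here, three have been measured in an assay on microsomes for inhibition of acyl-CoA:cholesterol acyltransferase (Oryctolagus cuniculus); a lower number here means a stronger inhibitor, a higher number a weaker inhibitor. Compound 1 and compound 2 sit close together, the step of a 1.1-fold lower number from compound 1 to compound 2 (0.05 log units; within the scatter) lying within the scatter. Compound 3 gives the highest of the three numbers: the steps of a 3.7-fold higher number from compound 1 to compound 3 (0.57 log units; beyond the scatter) and a 4.2-fold higher number from compound 2 to compound 3 (0.62 log units; beyond the scatter) are both modest but beyond the scatter.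

Compound 4 `CC(C)c1cccc(C(C)C)c1NC(=O)NCC1(c2ccc(Cl)cc2)CCCC1` differs from compound 3 by chloro in place of tert-butyl on an aromatic carbon. Among the measured compounds shown here, no measured step changes a group on the phenyl ring while keeping its place, so the two steps leading to compound 3 bear on the new step only loosely: in each, a tert-butyl at the para position accompanied the higher number. Compound 4 is therefore expected to give a number somewhat lower than compound 3, with an estimated step of a 1.8-fold lower number from compound 3 to compound 4 (0.26 log units; within the scatter) in this assay. Taking the wide uncertainty into account, compound 4 is expected to give 35 nM in this assay, with a range from 12 nM to 100 nM.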

Compound 4, half-maximal inhibitory concentration: 32 nM
For compound 4 the middle estimate is 1.1-fold (0.04 log units) above the measured one; the measured number falls inside the stated range.
By their numbers in this assay, from the lowest: compounds 2, 1, 4 and 3 (each within the scatter of the next, the first and the last beyond it).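

In this assay, this is the first step shown that changes the group while keeping its place on the phenyl ring, and replacing tert-butyl, with its 4 heavy atoms, by chloro, with 1, gives a 2.0-fold lower number from compound 3 to compound 4 (0.29 log units; within the scatter) at this carbon para to a large group. Set against the methylphenyl compounds, the 4-chlorophenyl compound shows a 1.9-fold higher number from compound 1 to compound 4 (0.27 log units; within the scatter) and a 2.1-fold higher number from compound 2 to compound 4 (0.33 log units; beyond the scatter) in the same assay, so only the second of these comparisons is a modest separation. Nothing measured here accounts for the size of these steps.

The compounds shown leave open how a methyl, a methoxy or a carboxylic acid would read at this same place. They also leave open whether chloro would read the same elsewhere on the phenyl ring.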